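Bromo for Butoxy: A Cytotoxicity Expectation

This account rests on a few compounds, and the source may have more. Where it says the series, first, only, none or still open, it means among the compounds named here.

For the measured compounds named here, compound 2 `CCCCOc1ccc2oc(/C=C/[S+](C)[O-])cc(=O)c2c1` gives 1400 nM in a functional assay on A549 cells (Homo sapiens) for cytotoxicity, with a stated time of 48 h (a lower number here means a stronger inhibitor, a higher number a weaker inhibitor), one of two numbers so far, and it sits within the scatter of compound 1 `C[S+]([O-])/C=C/c1cc(=O)c2ccccc2o1`, which gives 1900 nM in this assay. Going by the values given here, the single measured step, a 1.4-fold lower number from compound 1 to compound 2 (0.13 log units; within the scatter), concerns the same aromatic carbon that changes next. Compound 3 `C[S+]([O-])/C=C/c1cc(=O)c2cc(Br)ccc2o1` differs from compound 2 by bromo in place of butoxy on an aromatic carbon. That earlier step stayed within the scatter, so compound 3 is expected to show a 1.2-fold higher number from compound 2 to compound 3 (0.08 log units; within the scatter), no step beyond the scatter. Compound 3 is therefore estimated at 1700 nM, in a range from 800 nM to 3600 nM.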

Compound 3, half-maximal inhibitory concentration: 1100 nM
Beside the measured number, compound 3's estimate is 1.5-fold (0.19 log units) above it; low and high end bracket the measured number.
By their numbers in this assay, from the lowest: compounds 3, 2 and 1 (each within the scatter of the next).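

In this assay, bromo in place of butoxy (a 1.3-fold lower number from compound 2 to compound 3 (0.10 log units; within the scatter)) and bromo in place of hydrogen (a 1.7-fold lower number from compound 1 to compound 3 (0.24 log units; within the scatter)) both stay within the scatter. Hydrogen, butoxy and bromo on this aromatic carbon therefore cannot be told apart in this read-out, despite the difference in size between a butoxy chain and a single bromine. Nothing on hand accounts for this. As far as these compounds go, whether an amine or a carboxylic acid on this carbon would give a step beyond the scatter remains open. So does the outcome for a chain longer than butoxy.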